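The compounds below may be only part of what the source reports. "The series", "measured", "known", "first", "only" and "open" are said of these compounds alone.

Measured compounds:
- compound 1, `CS(=O)(=O)c1ccc(C(=O)NCC(=O)N(Cc2ccccc2)Cc2ccccc2)cc1[N+](=O)[O-]`: 11900 nM
- compound 2, `CS(=O)(=O)c1ccc(C(=O)NCCCC(=O)N2CCC(c3ccccc3)CC2)cc1[N+](=O)[O-]`: > 27000 nM
- compound 3, `CN(CC(=O)N1CCN(c2ccc(F)cc2)CC1)C(=O)c1ccc(S(C)(=O)=O)c([N+](=O)[O-])c1`: 17200 nM

The three share a nitro-substituted methylsulfonyl-benzamide core and were tested in an ADME assay on HepG2 cells (Homo sapiens) for cytotoxicity, read by CellTiter-Glo and ATP content, with a stated time of 72 h; a lower number here means that less compound is needed, a higher number that more compound is needed for the effect. Compound 1 gives 11900 nM there. Compound 3 gives 17200 nM, and the gap to compound 1 lies within the usual scatter, so the two cannot be set apart. The value of compound 2 is a limit of the assay rather than a number: the limit of > 27000 nM in this assay, at which 1 of the 3 values shown sits. Nothing beyond this can be read across the three, since no two of them differ in a single place.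

Compound 4, `CN(Cc1ccccc1)C(=O)CNC(=O)c1ccc(S(C)(=O)=O)c([N+](=O)[O-])c1`, has not yet been measured in this assay. It differs from compound 1 in one place: hydrogen in place of phenyl on a saturated chain carbon bound to an amide-type nitrogen. Within the data shown here, no measured pair shows this kind of change, so the step must be guessed. Since compound 1 sits at 11900 nM and the remaining finished number, that of compound 3, lies within scatter of it, the expectation is a step from compound 1 to compound 4 of a 1.5-fold higher number from compound 1 to compound 4 (0.18 log units; within the scatter), toward a higher number, of a size that may not exceed the scatter. For compound 4 the estimate in this assay is 18000 nM, with a range from 8000 nM to 40000 nM.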

Compound 4, half-maximal effective concentration: > 27000 nM
Compound 4 was reported as a limit; the forecaster's own chance of this, stated with the estimate: 25%; at least 1.5-fold (0.17 log units) between middle value and limit.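

In this assay compound 4 gives > 27000 nM, which is a limit of the assay and not a number. Among these compounds, this gives the first step in the set that can be read at a single place: hydrogen in place of phenyl on a saturated chain carbon bound to an amide-type nitrogen, or benzyl to methyl when cut one bond further out, gives an at least 2.2-fold higher number from compound 1 to compound 4 (0.35 log units; beyond the scatter), so at this place the loss of the phenyl raises the amount of compound needed for the effect. The full size of the step stays unknown, and such a limit is not a lone case among these compounds: the limit of > 27000 nM in this assay, at which 2 of the 4 values shown sit.

How a group of intermediate size would behave at this place stays open, as the phenyl and the hydrogen are the only two cases shown here. The compounds shown also leave open what a longer chain, an amine or a carboxylic acid would do on this same carbon, and whether any of them would bring the number back toward that of compound 1.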